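Swapping a Dichlorophenyl for a Small Ring: Lipophilicity Outlook

This account rests on a few compounds, and the source may have more. Where it says the series, first, only, none or still open, it means among the compounds named here.

Compound 1 `CSc1ccc2nc(C)cc(OCC(=O)Nc3cc(C)cc(C)c3)c2c1` gives 6.42 in a physicochemical assay for lipophilicity, read by HPLC, in phosphate buffer, measured as chromatographic lipophilicity, at pH 7.4; on this read-out higher numbers stand for higher lipophilicity and lower numbers for lower lipophilicity.
Compound 2 `COc1ccc2nc(C)cc(OCC(=O)Nc3ccc(Cl)cc3Cl)c2c1` gives 6.4 in this assay.

Of these two numbers, compound 2 has the lower one, yet its gap to compound 1 lies within the usual scatter, so the two compounds stand together. Compound 3 `COc1ccc2nc(C)cc(OCC(=O)NC3CONC3=O)c2c1` is not yet measured; it differs from compound 2 by a group of 6 heavy atoms (3 carbon, 1 nitrogen, 2 oxygen; one five-membered non-aromatic ring with 2 hetero atoms) in place of a group of 8 heavy atoms (6 carbon, 2 chlorine; one six-membered aromatic ring of carbon only), on an amide-type nitrogen. Among the measured compounds shown here, no measured pair shows the effect of such a change, but a group with no donors or acceptors leaves and one with one donor and two acceptors enters, so a large fall in this assay is expected: a number 3.90 log units lower from compound 2 to compound 3 (beyond the scatter). Compound 3 is estimated at 2.5, likely between 1.5 and 3.5.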

Compound 3, distribution coefficient: 0.79
Compound 3: the middle estimate sits 1.71 log units above what was measured; measured number outside the range, below it.
By their numbers in this assay, from the lowest: compound 3; then compounds 2 and 1 (each within the scatter of the next).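

In this assay, putting the five-membered non-aromatic ring in place of 2,4-dichlorophenyl on the amide-type nitrogen gives a number 5.61 log units lower from compound 2 to compound 3 (beyond the scatter), so one change at this place can move the read-out very far. The two earlier compounds, whose values stand together, could not show this. Nothing available here explains the size of the step.
The compounds shown leave open how much of the step belongs to the loss of the aromatic ring and how much to the hetero atoms. A cyclopentyl ring on the same nitrogen would help separate the two.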